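From amino to trifluoromethyl: what to expect for compound 3

This account rests on a few compounds, and the source may have more. Where it says the series, first, only, none or still open, it means among the compounds named here.

Compound 1 `CN1CCN(Cc2ccc(NC(=O)c3ccc(OCCCCl)c(S(N)(=O)=O)c3)cc2C(F)(F)F)CC1`: 5470 nM
Compound 2 `CN1CCN(Cc2ccc(NC(=O)c3ccc(OCCCCl)c(N)c3)cc2C(F)(F)F)CC1`: 12900 nM

In a toxicity assay on Huh-7.5 cells (Homo sapiens) for inhibition, read by MTT assay, with a stated time of 96 h (a lower number here means that less compound is tolerated, a higher number that more compound is tolerated), compound 2 gives 12900 nM, the higher of the two numbers, so it is the better tolerated of this pair. The next compound, compound 3 `CN1CCN(Cc2ccc(NC(=O)c3ccc(OCCCCl)c(C(F)(F)F)c3)cc2C(F)(F)F)CC1`, keeps the shared core and alters one group: trifluoromethyl in place of amino on an aromatic carbon. The new trifluoromethyl stands on an aromatic carbon, ortho to a 3-chloropropoxy group.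

Within the data shown here, only one measured step bears on this change, and it is modest: a 2.4-fold higher number from compound 1 to compound 2 (0.37 log units; beyond the scatter). That step also swaps a group on this aromatic carbon, with amino in place of sulfamoyl. Among the measured compounds shown here, it is thin evidence, as no compound with trifluoromethyl there has been measured yet. For the measured compounds named here, still, amino holds the higher number so far, so a modest step down in this assay is the more likely outcome, of about the size seen before. A step within the scatter remains possible.

The expected change is a 2.0-fold lower number from compound 2 to compound 3 (0.30 log units; within the scatter). For compound 3 the estimated value is 6500 nM, with an expected range of 2500 nM to 14000 nM.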

Compound 3, half-maximal cytotoxic concentration: 13400 nM
The estimate for compound 3 lay 2.1-fold (0.31 log units) below the measured number, within the range that was stated.
By their numbers in this assay, from the lowest: compound 1; then compounds 2 and 3 (each within the scatter of the next).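

In this assay the change from amino to trifluoromethyl gives a 1.0-fold higher number from compound 2 to compound 3 (0.02 log units; within the scatter) and so leaves the number effectively unmoved, even though 4 heavy atoms enter where 1 left and the hydrogen-bond donor and acceptor counted for amino are gone. Among the three groups seen on this aromatic carbon, ortho to a 3-chloropropoxy group, only sulfamoyl now stands apart: trifluoromethyl in its place gives a 2.4-fold higher number from compound 1 to compound 3 (0.39 log units; beyond the scatter) and amino in its place gave a 2.4-fold higher number from compound 1 to compound 2 (0.37 log units; beyond the scatter) in the same assay, so two very different replacements land at the same level. Nothing measured on these compounds explains why sulfamoyl differs from the other two groups or why amino and trifluoromethyl match.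

The compounds shown leave open whether this match extends to other groups at the same carbon, such as a carboxylic acid, a nitrile or a plain hydrogen, which would show whether sulfamoyl is the exception or one end of a wider spread. They also leave open whether amino and trifluoromethyl would still match if the 3-chloropropoxy group gave way to a longer chain.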